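Methoxy series: thiophen-3-yl in place of furan-2-yl

A few compounds are considered here, and "the series" means these few. Any claim that something is new, unique, unknown or untested is made for them only; others in the source may bear on it.

All values here come from a functional assay on K562 cells (Homo sapiens), read by MTT assay, with a stated time of 72 h; a lower number here means a stronger inhibitor, a higher number a weaker inhibitor. Compound 1 `Nc1nc(N)c2c(-c3ccsc3)cn([C@@H]3O[C@H](CO)[C@@H](O)[C@H]3O)c2n1` reports only a limit, > 20000 nM, not a number. Compound 2 `COc1nc(N)nc2c1c(-c1ccoc1)cn2[C@@H]1O[C@H](CO)[C@@H](O)[C@H]1O` likewise reports only a limit, > 20000 nM. Compound 3 `COc1nc(N)nc2c1c(-c1ccco1)cn2[C@@H]1O[C@H](CO)[C@@H](O)[C@H]1O` also reports only a limit, > 20000 nM. The step that the two limits leave unreadable from compound 2 to compound 3 is therefore unreadable, as both of its ends are limits. Compound 3 thus stands where every measured compound stands, at the limit (the limit of > 20000 nM in this assay, at which 3 of the 3 values shown sit), with no number anywhere in the series to anchor it.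

Compound 4 `COc1nc(N)nc2c1c(-c1ccsc1)cn2[C@@H]1O[C@H](CO)[C@@H](O)[C@H]1O` differs from compound 3 by thiophen-3-yl in place of furan-2-yl on an aromatic carbon. For the measured compounds named here, no measured step carries this exact change. Going by the values given here, compound 1 bears the same thiophen-3-yl group on the shared core and also reports only a limit, so nothing among the measured values suggests a move off the limit. The expected step is a step that the limit leaves unreadable from compound 3 to compound 4, that is, none beyond the scatter. Compound 4 is therefore expected at 30000 nM, within 15000 nM to 100000 nM, and most probably reported again only as a limit.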

Compound 4, half-maximal inhibitory concentration: > 20000 nM
Compound 4: no number, only a limit; the forecaster's own chance of this, stated with the estimate: 85%; the middle value lies beyond the limit too.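

Compound 4 sits at the same limit as compound 1, compound 2 and compound 3 in this assay, so none of its steps from those compounds can be read: the limit of > 20000 nM in this assay, at which 4 of the 4 values shown sit.

The compounds shown leave open whether any of these groups, on either core, gives a number rather than a limit in this assay.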